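Swapping a piperidine for an ethylpiperazine on the shared core

The source may hold more compounds than are shown below. What is called first, only, known or untested is meant among the compounds shown, and "the series" means these compounds.

Of the compounds shown here, three built on one shared core have been tested in a functional assay on SK-BR-3 cells (Homo sapiens) for antiproliferative activity, read by MTT assay, with a stated time of 72 h; a lower number here means a stronger inhibitor, a higher number a weaker inhibitor. Compound 1 `CCN1CCN(c2cc(C)c3cc(NC(=O)c4ccccc4)ccc3n2)CC1` gives 18400 nM in this assay. Compound 2 `Cc1cc(NCCN(C)C)nc2ccc(NC(=O)c3ccc(Cl)c(Cl)c3)cc12` gives 6670 nM. Compound 3 `Cc1cc(N2CCCCC2)nc2ccc(NC(=O)c3ccc(Cl)c(Cl)c3)cc12` gives 42500 nM, the highest number of the three, so it is the weakest inhibitor shown; compound 1 sits closer to it and compound 2 furthest away, and both gaps lie beyond the scatter.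

Going by the values given here, the one step measured between these compounds is a 6.4-fold higher number from compound 2 to compound 3 (0.80 log units; beyond the scatter), a modest change that came with piperidin-1-yl in place of (2-(dimethylamino)ethyl)amino on an aromatic carbon.

Compound 4 `CCN1CCN(c2cc(C)c3cc(NC(=O)c4ccc(Cl)c(Cl)c4)ccc3n2)CC1` is not yet measured. It differs from compound 3 in one place: 4-ethylpiperazin-1-yl in place of piperidin-1-yl on an aromatic carbon. Among the compounds with values here, no measured step covers this exact swap. Compound 1 carries the same 4-ethylpiperazin-1-yl group and sits below compound 3 in this assay, though it also lacks the two chlorines, so it only hints at the direction. On that basis compound 4 is expected to give a lower number than compound 3, a step of about a 4.3-fold lower number from compound 3 to compound 4 (0.63 log units; beyond the scatter). The estimate for compound 4 is 10000 nM, with a range from 3000 nM to 35000 nM.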

Compound 4, half-maximal inhibitory concentration: 2160 nM
Compound 4: middle estimate off by 4.6-fold (0.67 log units), on the high side; the measured number lies below the stated range.
By their numbers in this assay, from the lowest: compound 4; then compound 2; then compound 1; then compound 3.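

With the 3,4-dichlorophenyl amide held fixed, the group next to the ring nitrogen proves to be a strong control on the result in this assay: changing piperidin-1-yl to 4-ethylpiperazin-1-yl gives a 20-fold lower number from compound 3 to compound 4 (1.29 log units; beyond the scatter) and is the large step in this set. A six-membered ring at this position is therefore not a drawback in itself, since the earlier step suggested only that piperidin-1-yl did worse than the open chain, whereas the ethylpiperazine ring now gives a 3.1-fold lower number from compound 2 to compound 4 (0.49 log units; beyond the scatter) when it replaces that same chain. The other side of the molecule also gets its first clean comparison, as 3,4-dichlorophenyl in place of phenyl, with 4-ethylpiperazin-1-yl unchanged, gives an 8.5-fold lower number from compound 1 to compound 4 (0.93 log units; beyond the scatter) on the carbonyl carbon.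

These compounds leave open whether the ethyl group matters, which 4-methylpiperazin-1-yl or an unsubstituted piperazin-1-yl would test, and whether morpholin-4-yl would behave like either ring. No measurement shown accounts for the size of these steps, and the gain from a single chlorine on the phenyl also remains unknown.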